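The compounds below may be only part of what the source reports. "The series", "measured", "known", "first", "only" and "open" are said of these compounds alone.

In a functional assay on PC-3 cells (Homo sapiens) for cytotoxicity, read by MTT assay, with a stated time of 48 h (on this read-out lower numbers stand for stronger inhibition and higher numbers for weaker inhibition), compound 1 `[O-][n+]1nc(NCc2ccccc2)[n+]([O-])c2ccccc21` gives 10700 nM, and compound 2 `[O-][n+]1nc(NCc2ccccc2Cl)[n+]([O-])c2ccccc21` gives 10600 nM. Compound 2 holds the lowest of the two numbers, with compound 1 within the scatter of it, as the step of a 1.0-fold lower number from compound 1 to compound 2 (0.00 log units; within the scatter) shows. Compound 3 `[O-][n+]1nc(NCCO)[n+]([O-])c2ccccc21` differs from compound 2 by hydroxymethyl in place of 2-chlorophenyl on a saturated chain carbon bound to a nitrogen on an aromatic ring. Among the measured compounds shown here, no measured step covers a change of this kind; the only step seen, a 1.0-fold lower number from compound 1 to compound 2 (0.00 log units; within the scatter), concerns the ring that is now removed and lay within the scatter, so it offers little guidance. A step of a 1.7-fold higher number from compound 2 to compound 3 (0.23 log units; within the scatter) toward a higher number is expected. Compound 3 is therefore estimated at 18000 nM, within 6000 nM to 60000 nM.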

Compound 3, half-maximal inhibitory concentration: 22400 nM
Estimate against measurement, compound 3: 1.2-fold (0.09 log units) below; the measured number falls inside the stated range.
By their numbers in this assay, from the lowest: compounds 2 and 1 (each within the scatter of the next); then compound 3.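

In this assay, this place on the saturated chain carbon bound to a nitrogen on an aromatic ring now shows a change beyond the scatter: hydroxymethyl in place of 2-chlorophenyl gives a 2.1-fold higher number from compound 2 to compound 3 (0.32 log units; beyond the scatter), and hydroxymethyl in place of phenyl gives a 2.1-fold higher number from compound 1 to compound 3 (0.32 log units; beyond the scatter). Both steps are modest, so removing the aromatic ring here moves the number only slightly, though more than the chloro change on that ring did. Nothing available here accounts for this rise. The compounds shown leave open whether the rise follows from the departing ring or the entering hydroxyl. They also leave open how an amine, a carboxylic acid or a longer chain would read at this place.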